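The source may hold more compounds than are shown below. What is called first, only, known or untested is meant among the compounds shown, and "the series" means these compounds.

Compound 3, `CC(C)C[C@H](N)c1cc(C(F)(F)F)ccc1N1CCN(C(=O)COc2ccc(O)cc2)CC1`, gives 4600 nM in an assay on HEK293 cells for displacement of a labelled ligand from Melanocortin receptor 4 (Homo sapiens) (on this read-out higher numbers stand for weaker inhibition and lower numbers for stronger inhibition), the highest of the three numbers measured here. Its nearest neighbour is compound 1, `Cc1ccc(CC(C)C(=O)N2CCN(c3ccc(C(F)(F)F)cc3[C@@H](N)CC(C)C)CC2)cc1C`, which in this assay gives 240 nM; the most distant is compound 2, `COc1cc(Cl)ccc1C[C@@H](C)C(=O)N1CCN(c2ccc(C)cc2[C@@H](N)CC(C)C)CC1`, which gives 8.1 nM. Among the compounds with values here, the only single-place step that reaches compound 3 is a 19-fold higher number from compound 1 to compound 3 (1.28 log units; beyond the scatter), from 1-(3,4-dimethylbenzyl)ethyl to (4-hydroxyphenoxy)methyl on the carbonyl carbon. Compound 4, `CC(C)C[C@H](N)c1cc(C(F)(F)F)ccc1N1CCN(C(=O)CSc2ccc(Cl)cc2Cl)CC1`, differs from compound 3 by (2,4-dichlorophenyl)sulfanyl in place of 4-hydroxyphenoxy on a saturated chain carbon bound to a carbonyl carbon. Within the data shown here, no measured pair shows exactly this exchange. The step of a 19-fold higher number from compound 1 to compound 3 (1.28 log units; beyond the scatter) is the one that bears on it: the 4-hydroxyphenoxy group at this place accompanies the weakest number, while the 1-(3,4-dimethylbenzyl)ethyl group of compound 1 accompanies a far lower one. Among the measured compounds shown here, compound 2 differs from compound 3 in more than one place and gives no step. For the measured compounds named here, compound 4 brings in a (2,4-dichlorophenyl)sulfanyl group, an aromatic ring bearing chlorines and no hydrogen-bond donor, which is closer in kind to the group of compound 1 than to that of compound 3, so a move back toward lower numbers is expected, of roughly the size seen in the one relevant step. The expected step is therefore a 7.7-fold lower number from compound 3 to compound 4 (0.88 log units; beyond the scatter). For compound 4 the estimate in this assay is 600 nM, with a range from 150 nM to 2500 nM.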

Compound 4, inhibition constant: 1500 nM
Compound 4: the middle estimate sits 2.5-fold (0.40 log units) below what was measured; the measured number falls inside the stated range.
By their numbers in this assay, from the lowest: compound 2; then compound 1; then compound 4; then compound 3.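

Exchanging 4-hydroxyphenoxy for (2,4-dichlorophenyl)sulfanyl on a saturated chain carbon bound to a carbonyl carbon gives a 3.1-fold lower number from compound 3 to compound 4 (0.49 log units; beyond the scatter), so in this assay the number at this place moves with a change that keeps the six-membered aromatic ring of carbon only but replaces the oxygen with sulfur, the hydroxy group with two chlorines, and one hydrogen-bond donor with none. That recovery is only partial, as a 6.3-fold higher number from compound 1 to compound 4 (0.80 log units; beyond the scatter) shows: ((2,4-dichlorophenyl)sulfanyl)methyl on the carbonyl carbon still stands well on the weaker side of 1-(3,4-dimethylbenzyl)ethyl, and the larger part of the distance separating the two groups of compound 1 and compound 3 remains. No measurement is available to explain why the number shifts at this place.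

From the compounds shown here alone, since sulfur, the chlorines and the loss of the hydroxy group arrive in a single step, their separate shares remain unknown, and a 2,4-dichlorophenoxy group or a 4-hydroxyphenylsulfanyl group would be needed to pull them apart. Going by these compounds, it also remains open how a longer chain between the carbonyl carbon and the ring, or a branching methyl on the saturated chain carbon, would read at this place.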